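Swapping the hydroxyphenyl arm of compound 1 for a dimethylaminophenyl

The source may report more compounds than this note shows. Statements on the series, on what has been measured and on what is new or still open speak of the compounds shown alone.

Of the compounds shown here, three with a shared core have been tested in a functional assay on cells (Cancer cell lines, Homo sapiens) for cytotoxicity, read by sulforhodamine B assay, with a stated time of 48 h; on this read-out lower numbers stand for stronger inhibition of growth and higher numbers for weaker inhibition of growth. Compound 1 `O=C1N=C(N2N=C(c3ccccc3)CC2c2ccccc2O)S/C1=C1/C(=O)Nc2ccccc21` gives 2050 nM, the highest of the three numbers, so it is the weakest grower-inhibitor measured here. Compound 2 `O=C1N=C(N2N=C(c3ccccc3)CC2c2ccccc2O)S/C1=C1/C(=O)Nc2ccc(Br)cc21` gives 290 nM, and compound 3 `O=C1N=C(N2N=C(c3ccc4ccccc4c3)CC2c2ccc(Cl)cc2)S/C1=C1/C(=O)Nc2ccccc21` gives 400 nM. Within the data shown here, the only single-place step is a 7.1-fold lower number from compound 1 to compound 2 (0.85 log units; beyond the scatter); compound 3 differs from compound 1 in two places at once, so its lower number can only be noted, not assigned to either change.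

Compound 4 `CN(C)c1ccc(C2CC(c3ccccc3)=NN2C2=NC(=O)/C(=C3\C(=O)Nc4ccccc43)S2)cc1` has not been measured. It differs from compound 1 by 4-(dimethylamino)phenyl in place of 2-hydroxyphenyl on a saturated ring carbon. No measured step touches this saturated ring carbon alone, so nothing shown bears directly on it. Compound 3 also carries a different aryl group there and sits lower than compound 1, which hints gently downward, but the hint is not clean. For compound 4 the expected step is therefore a 1.7-fold lower number from compound 1 to compound 4 (0.23 log units; within the scatter), a small shift toward lower numbers that may stay within the scatter. The estimate for compound 4 in this assay is 1200 nM, within a range of 350 nM to 4000 nM.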

Compound 4, concentration for 50% growth inhibition: 270 nM
Beside the measured number, compound 4's estimate is 4.4-fold (0.65 log units) above it, outside the stated range (below it).
By their numbers in this assay, from the lowest: compounds 4, 2 and 3 (each within the scatter of the next); then compound 1.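

This result shows that the saturated ring carbon is a place where the choice of aryl group can move the number in this assay: replacing 2-hydroxyphenyl with 4-(dimethylamino)phenyl gives a 7.6-fold lower number from compound 1 to compound 4 (0.88 log units; beyond the scatter). Among these compounds, until now, the only single-place step was the bromo change on an aromatic carbon, so this is the first step to touch the saturated ring carbon alone. The leaving group carries a hydrogen-bond donor and the entering group has none, but nothing measured here says whether that or anything else accounts for the step.

Going by these compounds, it remains open whether an unsubstituted phenyl or a 4-methoxyphenyl at this carbon would sit nearer compound 1 or compound 4, which would help separate losing the hydroxy group from gaining the dimethylamino group. Whether adding bromo to compound 4 would lower its number further is also unknown.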